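The source may hold more compounds than are shown below. What is called first, only, known or untested is meant among the compounds shown, and "the series" means these compounds.

Measured so far:
- compound 1 `CCCCc1ccc(S(=O)(=O)NCCCCCCNCc2ccc(Br)cc2)cc1` — 5700 nM
- compound 2 `O=S(=O)(NCCCCCCNCc1ccc(Br)cc1)c1ccccc1Cl` — 13700 nM

Both values come from a functional assay on MIA PaCa-2 cells (Homo sapiens) for inhibition, read by MTT assay, with a stated time of 72 h; a lower number here means a stronger inhibitor of growth, a higher number a weaker inhibitor of growth. In this assay compound 1 gives 5700 nM, and compound 2 gives 13700 nM. Compound 2 thus holds the highest number of the two, and its gap to compound 1 lies beyond the usual scatter of this measurement, so compound 2 is read as the weaker growth inhibitor of the pair. Within the data shown here, nothing more can be said of the pair, as no single-change step between them has been worked out.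

The next compound, compound 3 `O=S(=O)(NCCCCCCNCc1ccc(Br)cc1)c1ccc2c(c1)OCC2`, is not yet measured in this assay. It differs from compound 2 in one place:
a group of 9 heavy atoms (8 carbon, 1 oxygen; one five-membered non-aromatic ring with 1 hetero atom, one six-membered aromatic ring of carbon only) in place of a group of 7 heavy atoms (6 carbon, 1 chlorine; one six-membered aromatic ring of carbon only), on a sulfonyl sulfur

Among the measured compounds shown here, no measured step of this kind exists, so the expectation for compound 3 rests on compound 2 alone and is loose. The expected step from compound 2 to compound 3 in this assay is a 1.5-fold lower number from compound 2 to compound 3 (0.18 log units; within the scatter), a small move towards a lower number that may well stay within the scatter. For compound 3 the estimate in this assay is 9000 nM, with a range from 3000 nM to 27000 nM.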

Compound 3, concentration for 50% growth inhibition: 13000 nM
The estimate for compound 3 lay 1.4-fold (0.16 log units) below the measured number, and the stated range covers the measured number.
By their numbers in this assay, from the lowest: compound 1; then compounds 3 and 2 (each within the scatter of the next).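

At the sulfonyl sulfur, whose other neighbour is the sulfonamide nitrogen, the series now has its first single-change step: in this assay, replacing 2-chlorophenyl with the group carrying a five-membered non-aromatic ring and a six-membered aromatic ring gives a 1.1-fold lower number from compound 2 to compound 3 (0.02 log units; within the scatter), which lies within the scatter. This position therefore tolerates the loss of the chlorine, a larger group and the gain of a hydrogen-bond acceptor without a change that can be read in this growth-inhibition measurement, although one step on one pair cannot show how general that tolerance is. No supporting measurement bears on why the two groups read alike.

On these data alone, it remains open whether a substituent with different atoms on the aromatic ring at this sulfonyl position, such as a carboxylic acid or an amine, would leave the number equally unmoved. The compounds shown also leave open how the read-out responds to changes elsewhere in the shared core, for example a shorter chain in place of the six-carbon linker, or a nitrile in place of the bromine.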